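Moving the trifluoromethyl group on the aryloxy ketone

This account rests on a few compounds, and the source may have more. Where it says the series, first, only, none or still open, it means among the compounds named here.

Values in a functional assay on Jurkat cells (Homo sapiens); a lower number here means a stronger inhibitor, a higher number a weaker inhibitor:
compound 1 `CC(C)[C@H](NC(=O)COc1cccc2ccccc12)C(=O)N[C@@H](CC(=O)O)C(=O)COc1ccccc1`: 14000 nM
compound 2 `CC(C)[C@H](NC(=O)COc1cccc2ccccc12)C(=O)N[C@@H](CC(=O)O)C(=O)COc1ccc2ccccc2c1`: > 100000 nM, a limit of the assay
compound 3 `CC(C)[C@H](NC(=O)COc1cccc2ccccc12)C(=O)N[C@@H](CC(=O)O)C(=O)COc1cccc(C(F)(F)F)c1`: > 100000 nM, a limit of the assay

Compound 3 gives no number, only a limit of the assay, > 100000 nM. It sits at the limit of > 100000 nM in this assay, at which 2 of the 3 values shown sit.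

Compound 4 `CC(C)[C@H](NC(=O)COc1cccc2ccccc12)C(=O)N[C@@H](CC(=O)O)C(=O)COc1ccc(C(F)(F)F)cc1` carries the same trifluoromethyl group at a different ring position: 4-(trifluoromethyl)phenyl in place of 3-(trifluoromethyl)phenyl on an oxygen on a saturated carbon. The change lies on an oxygen on a saturated carbon.

For the measured compounds named here, no measured step covers the 4-(trifluoromethyl)phenyl group itself. The closest evidence is an at least 7.1-fold higher number from compound 1 to compound 3 (0.85 log units; beyond the scatter), supported by an at least 7.1-fold higher number from compound 1 to compound 2 (0.85 log units; beyond the scatter). Going by the values given here, each of these starts from the only compound with a number and ends at the limit. The remaining comparison, a step that the two limits leave unreadable from compound 2 to compound 3, offers no size to carry over.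

On that basis, compound 4 is expected to remain weak in this assay, with no change beyond the scatter expected and a reported limit quite possible. The expected step is an at least 1.4-fold lower number from compound 3 to compound 4 (0.15 log units; that floor lies within the scatter).

Compound 4 is estimated at 70000 nM, with an expected range of 20000 nM to 150000 nM.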

Compound 4, half-maximal inhibitory concentration: > 100000 nM
Compound 4: no number, only a limit; the forecaster's own chance of this, stated with the estimate: 55%; middle value at least 1.4-fold (0.15 log units) from the limit.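

In this assay, compound 4 gives > 100000 nM, a limit of the assay, so changing 3-(trifluoromethyl)phenyl to 4-(trifluoromethyl)phenyl on this oxygen yields no readable value. Trifluoromethyl in place of hydrogen on the phenyl ring now gives a step beyond the scatter at a second ring position: an at least 7.1-fold higher number from compound 1 to compound 4 (0.85 log units; beyond the scatter). The steps from compound 2 and from compound 3 to compound 4 cannot be read, and all three compounds with a group other than plain phenyl here now share one ceiling: the limit of > 100000 nM in this assay, at which 3 of the 4 values shown sit.

Going by these compounds, how far compound 2, compound 3 and compound 4 lie beyond that limit stays open, as does any order among them. Also open, on these data alone, is whether a smaller ring substituent, such as a single fluorine or a methyl group, would stay near compound 1 at 14000 nM.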